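The compounds below may be only part of what the source reports. "The series", "measured", "known", "first", "only" and "open" are said of these compounds alone.

Measured so far in an assay on CHO cells for displacement of a labelled ligand from adenosine receptor A1 (Homo sapiens), read by scintillation counting, with a stated time of 120 min, tested at 10 uM; a higher number here means more inhibition at the concentration tested (going by the name of the read-out), a lower number less inhibition:
- compound 1, `Nc1scc(CN2CCN(c3ccc(Cl)cc3Cl)CC2)c1C(=O)c1ccc(Cl)cc1`: 0%
- compound 2, `Nc1scc(CN2CCN(c3ccc(F)cc3F)CC2)c1C(=O)c1ccc(Cl)cc1`: 1%

Two compounds of the series have numbers in this assay. Compound 1 gives 0%. Compound 2 gives 1%. Within the data shown here, the one step between them, a number 1 percentage points higher from compound 1 to compound 2 (within the scatter), lies within the scatter, so the two are not distinguished. Compound 2 stands at the top of the two numbers shown, with compound 1 nearest, but that standing carries no weight given the size of the gap.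

Compound 3, `Nc1scc(CN2CCN(c3cccc(F)c3F)CC2)c1C(=O)c1ccc(Cl)cc1`, has not been measured. It differs from compound 2 in one place: 2,3-difluorophenyl in place of 2,4-difluorophenyl on an amine nitrogen in a ring. Among the measured compounds shown here, the only measured step that bears on this part of the molecule is a number 1 percentage points higher from compound 1 to compound 2 (within the scatter), which also exchanges the group on the amine nitrogen in the ring and produced nothing beyond the scatter. Both measured compounds sit at the floor of the read-out. With no evidence that changes at this position move the number, compound 3 is expected to stay at that floor: the expected step is a number 1 percentage points higher from compound 2 to compound 3 (within the scatter). Compound 3 is estimated at 2%, with a range of -8% to 12%.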

Compound 3, a percentage reported as inhibition, at one concentration (the size of the read-out at that concentration, not a potency): 0%
Compound 3: middle estimate off by 2 percentage points, on the high side, within the range that was stated.
By their numbers in this assay, from the lowest: compounds 1, 3 and 2 (each within the scatter of the next).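

In this assay, the change from 2,4-difluorophenyl to 2,3-difluorophenyl, with the same atoms joined differently, gives a number 1 percentage points lower from compound 2 to compound 3 (within the scatter). The exchange of 2,4-dichlorophenyl for 2,3-difluorophenyl gives no change at the digits printed from compound 1 to compound 3 (within the scatter), so the three groups on the amine nitrogen in the ring are not distinguished, and a change in where the fluorines sit on the phenyl now joins the earlier change of halogen as a change that moves nothing beyond the scatter. No measurement at hand offers an explanation for this flat result.

All three compounds carry two halogens on the phenyl, which leaves open whether a carboxylic acid or an amine on that phenyl would give a number beyond the scatter in this assay. Also open, on these data alone, is whether the lack of inhibition at the concentration tested belongs to the shared core, which stays the same in all three compounds, rather than to the group on the amine nitrogen.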